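The source may report more compounds than this note shows. Statements on the series, on what has been measured and on what is new or still open speak of the compounds shown alone.

Measured compounds: compound 1, `CC(C)(C)C(=O)N1CCNCC1c1ccccc1`, 2.5; compound 2, `CN1CCC(C(=O)N2N=CCC2c2ccccc2)CC1`, 1.1.

In a physicochemical assay for lipophilicity, read by HPLC, measured as chromatographic lipophilicity, at pH 7.4 (a higher number here means a more lipophilic compound, a lower number a more polar compound), compound 1 gives 2.5, the higher of the two numbers, while compound 2 gives 1.1, lower by a margin beyond the usual scatter. Compound 3, `CN1CCN(C(=O)C(C)(C)C)C(c2ccccc2)C1`, has not yet been measured in this assay. Relative to compound 1 the change is methyl in place of hydrogen on an amine nitrogen in a ring. Within the data shown here, no measured pair shows this step, so its size is unknown from these data. A modest rise in this assay is expected, the estimated step being a number 0.40 log units higher from compound 1 to compound 3 (beyond the scatter). Compound 3 is accordingly estimated at 2.9, with a range of 2.5 to 3.3.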

Compound 3, distribution coefficient: 4.9
The estimate for compound 3 lay 2.00 log units below the measured number; measured number above the stated range.
By their numbers in this assay, from the lowest: compound 2; then compound 1; then compound 3.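

In this assay, among these compounds, methyl in place of hydrogen on an amine nitrogen in a ring gives the first readable step at this position, and a large one, a number 2.40 log units higher from compound 1 to compound 3 (beyond the scatter) in a single change. That change adds only one carbon, with no ring and no hydrogen-bond donor or acceptor. No available evidence accounts for the size of this step. Going by these compounds, whether an ethyl group, a longer chain or an acetyl group on the same nitrogen would give a step of similar size stays open. So does whether the methyl step would recur on another core.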